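This account rests on a few compounds, and the source may have more. Where it says the series, first, only, none or still open, it means among the compounds named here.

Measured so far in a functional assay on CHO cells for agonist activity at Glucose-dependent insulinotropic receptor (Homo sapiens), read by a luciferase reporter and cAMP accumulation, with a stated time of 2 h; on this read-out higher numbers stand for an effect only at larger amounts of compound and lower numbers for an effect already at smaller amounts:
compound 1, `CC(C)(C)OC(=O)N1CCC(CCOC(=O)N2CCc3cc(S(C)(=O)=O)c(F)cc32)CC1`: compound 1 gives 160 nM
compound 2, `COc1cc2c(cc1S(C)(=O)=O)CCN2C(=O)OCCC1CCN(C(=O)OC(C)(C)C)CC1`: compound 2 gives 4800 nM
compound 3, `CC(C)OC(=O)N1CCC(Oc2cc(N3CCc4cc(S(C)(=O)=O)ccc43)ncn2)CC1`: compound 3 gives 17 nM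

Compound 3 stands lowest of the three numbers in this assay; compound 1 is nearest to it and compound 2 furthest, and both gaps lie beyond the scatter. Compound 4, `CC(C)c1noc(N2CCC(Oc3cc(N4CCc5cc(S(C)(=O)=O)ccc54)ncn3)CC2)n1`, has not yet been measured. It differs from compound 3 in one place: 3-isopropyl-1,2,4-oxadiazol-5-yl in place of isopropoxycarbonyl on an amine nitrogen in a ring. Going by the values given here, none of the measured steps touches this position. Among the compounds with values here, the one step that is known, a 30-fold higher number from compound 1 to compound 2 (1.48 log units; beyond the scatter), concerns a substituent on an aromatic carbon of the shared core and says nothing about the group on the ring nitrogen. Within the data shown here, no measured compound carries the oxadiazole, so the expectation rests on compound 3 and its 17 nM alone. The step of a 1.4-fold lower number from compound 3 to compound 4 (0.15 log units; within the scatter) is therefore expected to be small, within or near the scatter, with no direction that the data can support. The estimate for compound 4 in this assay is 12 nM, with a range from 3 nM to 60 nM.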

Compound 4, half-maximal effective concentration in the Glucose-dependent insulinotropic receptor assay: 7.7 nM
Compound 4: middle estimate off by 1.6-fold (0.19 log units), on the high side; low and high end bracket the measured number.
By their numbers in the Glucose-dependent insulinotropic receptor assay, from the lowest: compound 4; then compound 3; then compound 1; then compound 2.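

Going by these compounds alone, in the Glucose-dependent insulinotropic receptor assay the amine nitrogen in the six-membered ring, a position no earlier step had touched, takes 3-isopropyl-1,2,4-oxadiazol-5-yl in place of isopropoxycarbonyl with a 2.2-fold lower number from compound 3 to compound 4 (0.34 log units; beyond the scatter) as the outcome, so a carbonyl-bearing group on this nitrogen is not needed for activity in this pair, and an aromatic five-membered ring with three hetero atoms serves there. In a physicochemical assay for lipophilicity, read by HPLC, measured as octanol-water partition, at pH 7.4 (on this read-out lower numbers stand for lower lipophilicity and higher numbers for higher lipophilicity), the same exchange gives no change at the digits printed from compound 3 to compound 4 (within the scatter) with compound 3 reading 3.1 and compound 4 reading 3.1 on the scale, so the step in the receptor assay comes without any measured shift in the distribution coefficient. Nothing available here explains why the receptor number moves with this exchange.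

The compounds shown leave open whether the step belongs to the oxadiazole ring or to its isopropyl group, which a methyl, a cyclopropyl or a tert-butyl on the same ring, or a pyrimidine on the same nitrogen, would help to separate. They also leave open whether a fluoro or methoxy group on an aromatic carbon of the shared core would act in the same way alongside the oxadiazole as it does alongside a carbamate-type tert-butoxycarbonyl group.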